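Dropping the Fluorine from a Benzyl Ether

The compounds below may be only part of what the source reports. "The series", "measured", "known", "first", "only" and "open" are said of these compounds alone.

Compound 1, `CN(C)CCNc1ccnc2cc(OCc3ccc(F)cc3)ccc12`: 580 nM
Compound 2, `CC(C)COc1ccc2c(Cl)ccnc2c1`: 2680 nM

Both values come from a functional assay on RKO cells (Homo sapiens) for cytotoxicity, read by MTT assay, with a stated time of 48 h; a higher number here means a weaker inhibitor, a lower number a stronger inhibitor. Compound 1 stands lowest of the two numbers; its nearest neighbour, compound 2, gives a higher number, and that gap lies beyond the scatter. The two compounds share a core but differ in several places at once, so their pair says nothing about any single change.

Compound 3, `CN(C)CCNc1ccnc2cc(OCc3ccccc3)ccc12`, has not yet been measured in this assay. It differs from compound 1 in one place: hydrogen in place of fluoro on an aromatic carbon. Among the compounds with values here, no measured pair shows this change on its own, so the expectation rests on the structures and on the value of compound 1 alone. A single fluorine leaving for hydrogen on the benzyl group is a small alteration, and the step from compound 1 to compound 3 is expected to be a 1.2-fold higher number from compound 1 to compound 3 (0.08 log units; within the scatter), none beyond the scatter in either direction. Compound 3 is therefore estimated to give 700 nM in this assay, with a range from 300 nM to 1700 nM.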

Compound 3, half-maximal inhibitory concentration: 2350 nM
For compound 3 the middle estimate is 3.4-fold (0.53 log units) below the measured one, outside the stated range (above it).
By their numbers in this assay, from the lowest: compound 1; then compounds 3 and 2 (each within the scatter of the next).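

Within the data shown here, the first change that can be read on its own here is hydrogen in place of fluoro on the benzyl group, and in this assay it brings a 4.1-fold higher number from compound 1 to compound 3 (0.61 log units; beyond the scatter) on the way from the 4-fluorobenzyl to the plain benzyl ether. Since a higher number means a weaker inhibitor, and this step lies beyond the scatter, the aromatic carbon para to a large group is not a place where a substituent can be changed freely: removing one fluorine atom, and nothing else, is enough to move the reading. Nothing available here explains this difference, so the result stands as an observation without a known cause.

With only fluoro and hydrogen shown at this carbon, it remains open whether chlorine, a methyl group or a methoxy group would match the 4-fluorobenzyl ether, fall back to the benzyl ether or go beyond both. Also open, going by these compounds, is whether the fluorine would give the same step with a longer chain between the ether oxygen and the phenyl ring.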